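The source may report more compounds than this note shows. Statements on the series, on what has been measured and on what is new or still open speak of the compounds shown alone.

In an ADME assay on a cell-free system (plasma, Mus musculus, strain C57BL/6) for metabolic stability, read by HPLC, with a stated time of 12 h (on this read-out higher numbers stand for a longer-lived compound and lower numbers for a shorter-lived compound), compound 3 `O=C(N[C@H](CO)C(=O)O)[C@@H]1C[C@@H](O)CN1` gives > 12 h, a limit of the assay and not a number. Compound 1 `O=C(O)[C@@H](CO)NC(=O)[C@H]1C[C@@H](O)CN1` gives > 12 h, also a limit. Compound 2 `O=C(O)[C@H](CO)NC(=O)[C@@H]1C[C@H](O)CN1` gives > 12 h, again a limit. Together these show (the limit of > 12 h in this assay, at which 3 of the 3 values shown sit).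

Compound 4 `O=C(O)[C@H](CO)NC(=O)[C@@H]1C[C@@H](O)CN1` departs from compound 3 by a single change: the two compounds have the same atoms and bonds and differ only in configuration as drawn: 1 of 3 stereo elements differ; a stereocentre at a saturated chain carbon is drawn R in compound 3 and S in compound 4. Three measured changes of configuration bear on it: a step that the two limits leave unreadable from compound 1 to compound 2, a step that the two limits leave unreadable from compound 1 to compound 3 and a step that the two limits leave unreadable from compound 2 to compound 3. None of them has a readable size. Because a step that the two limits leave unreadable from compound 2 to compound 3 also alters a stereocentre at a saturated chain carbon and leaves both compounds at a limit, no shift beyond the scatter is expected, in either direction. The expected change is a step that the limit leaves unreadable from compound 3 to compound 4. Compound 4 is estimated at 20 h, with an expected range from 12 h to 40 h.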

Compound 4, half-life: > 12 h
Compound 4 ended at the assay's limit; the forecaster's own chance of this, stated with the estimate: 90%; the middle value does not contradict the limit.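

No step linking compound 4 with compound 1, compound 2 or compound 3 can be read in this assay: the limit of > 12 h in this assay, at which 4 of the 4 values shown sit.

The compounds shown leave open whether configuration affects half-life at all, and how long each compound actually lasts.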